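Chloro in place of fluoro: a small step expected

The source may report more compounds than this note shows. Statements on the series, on what has been measured and on what is new or still open speak of the compounds shown alone.

In a functional assay on HCT-116 cells (Homo sapiens) for antiproliferative activity, read by MTT assay, with a stated time of 48 h (a higher number here means a weaker inhibitor, a lower number a stronger inhibitor), compound 1 `COc1ccc(N(C)c2ccnc(Cl)n2)cc1` gives 1460 nM, and its fluoro counterpart, compound 2 `COc1ccc(N(C)c2ccnc(Cl)n2)cc1F`, gives 914 nM. Going by the values given here, of the two numbers available so far, that of compound 2 therefore stands within the scatter of compound 1. The next structure, compound 3 `COc1ccc(N(C)c2ccnc(Cl)n2)cc1Cl`, carries chloro in place of fluoro on an aromatic carbon, ortho to a methoxy group: chloro in place of fluoro on an aromatic carbon. Among the compounds with values here, only one measured step bears on this change, the fluoro in place of hydrogen at that same carbon, which amounted to a 1.6-fold lower number from compound 1 to compound 2 (0.20 log units; within the scatter). As far as these compounds go, with so modest a precedent, no shift beyond the scatter is expected in this assay, and the direction stays open. The expected change is a 1.1-fold lower number from compound 2 to compound 3 (0.06 log units; within the scatter). For compound 3 the estimated value is 800 nM, with an expected range from 350 nM to 1800 nM.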

Compound 3, half-maximal inhibitory concentration: 1170 nM
Compound 3: the middle estimate sits 1.5-fold (0.17 log units) below what was measured; measured number inside the range.
By their numbers in this assay, from the lowest: compounds 2, 3 and 1 (each within the scatter of the next).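

In this assay, chloro in place of fluoro on the aromatic carbon ortho to a methoxy group gives a step that stays within the scatter (a 1.3-fold higher number from compound 2 to compound 3 (0.11 log units; within the scatter)), and chloro in place of hydrogen at that same carbon does too (a 1.2-fold lower number from compound 1 to compound 3 (0.10 log units; within the scatter)). With the fluoro step from before, all three exchanges among hydrogen, fluoro and chloro at this carbon are now read, and none of them leaves the scatter, so the three compounds cannot be ordered by this change. No measurement shown gives a reason for these small steps. As far as these compounds go, whether an amine, a carboxylic acid or a longer chain at this carbon would produce a step beyond the scatter remains open. The three compounds also leave open whether the same exchanges would behave alike on another core.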